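Notes on removing the (cyclohexylmethyl)sulfanyl group

A few compounds are considered here, and "the series" means these few. Any claim that something is new, unique, unknown or untested is made for them only; others in the source may bear on it.

Compound 1 `Cc1cc(Nc2ccn(Cc3ccccc3)n2)n2nc(SCc3ccc(Br)cc3)nc2n1` gives 44400 nM in an ADME assay on GES1 cells (Homo sapiens) for inhibition, read by MTT assay, with a stated time of 72 h; a lower number here means a stronger inhibitor, a higher number a weaker inhibitor. Compound 2 `Cc1cc(Nc2cc(-c3ccccc3)[nH]n2)n2nc(SCC3CCCCC3)nc2n1` reports only a limit of this assay, namely > 50000 nM. For the measured compounds named here, the sole guide on the series is the limit of > 50000 nM in this assay, at which 1 of the 2 values shown sits, so compound 2 stands at the ceiling of what this assay resolves. Compound 3 `Cc1cc(Nc2cc(-c3ccccc3)[nH]n2)n2ncnc2n1` differs from compound 2 by hydrogen in place of (cyclohexylmethyl)sulfanyl on an aromatic carbon. Going by the values given here, no step between measured compounds exists, so the size of this change in this assay cannot be read from data; the expectation is for no shift beyond the scatter, with a limit likely again. Compound 3 is expected at 60000 nM, within 30000 nM to 150000 nM. The step that the limit leaves unreadable from compound 2 to compound 3 is estimated to remain near the limit.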

Compound 3, half-maximal inhibitory concentration: > 50000 nM
Compound 3: only a limit was reported; the forecaster's own chance of this, stated with the estimate: 70%; the middle value does not contradict the limit.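

For the compounds shown here, compound 2 and compound 3 both give only limits in this assay, so no step between them can be read. From the compounds shown here alone, whether hydrogen in place of (cyclohexylmethyl)sulfanyl shifts the read-out at all remains open.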